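The source may hold more compounds than are shown below. What is called first, only, known or untested is meant among the compounds shown, and "the series" means these compounds.

Within the data shown here, in an assay on HEK293 cells for displacement of a labelled ligand from Melanocortin receptor 4 (Homo sapiens) (on this read-out lower numbers stand for stronger inhibition and higher numbers for weaker inhibition), compound 2 `CC(C)C[C@H](N)c1cc(C(F)(F)F)ccc1N1CCN(C(=O)CCNC2CCCCC2)CC1` gives 4800 nM, the only actual number in this small set. Compound 1 `CC(C)C[C@H](N)c1cc(C(F)(F)F)ccc1N1CCN(C(=O)CCC(N)=O)CC1` sits at a limit of the assay, > 10000 nM. Among the measured compounds shown here, the single measured step, an at least 2.0-fold lower number from compound 1 to compound 2 (0.31 log units; beyond the scatter), swapped a carbamoyl for a cyclohexylamino group. Compound 3 `CC(C)C[C@H](N)c1cc(C(F)(F)F)ccc1N1CCN(C(=O)COc2ccc([N+](=O)[O-])cc2)CC1` differs from compound 2 by 4-nitrophenoxy in place of (cyclohexylamino)methyl on a saturated chain carbon bound to a carbonyl carbon, removing that amine again. Compound 1 likewise carries no such amine and shows only (the limit of > 10000 nM in this assay, at which 1 of the 2 values shown sits). A weakening is therefore expected, estimated as a 3.1-fold higher number from compound 2 to compound 3 (0.49 log units; beyond the scatter). Compound 3 is expected to reach about 15000 nM, in the range 3000 nM to 60000 nM.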

Compound 3, inhibition constant: 3100 nM
For compound 3 the middle estimate is 4.8-fold (0.68 log units) above the measured one, within the range that was stated.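

In this assay, 4-nitrophenoxy in place of (cyclohexylamino)methyl on a saturated chain carbon bound to a carbonyl carbon gives a 1.5-fold lower number from compound 2 to compound 3 (0.19 log units; within the scatter). An amine in this side chain is therefore not required to reach this level of binding. Among these compounds, replacing carbamoylmethyl with 4-nitrophenoxy at the same place gives an at least 3.2-fold lower number from compound 1 to compound 3 (0.50 log units; beyond the scatter), so the amine is not the only group that improves on carbamoylmethyl here.

The compounds shown leave open whether the nitro group or the ether oxygen matters. A plain phenoxy or a benzyl group at this place would help separate those parts.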